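Amide series: para group of the anilide in paw edema

This account rests on a few compounds, and the source may have more. Where it says the series, first, only, none or still open, it means among the compounds named here.

Measured so far in a functional assay on the whole organism for inhibition, with Rattus norvegicus as the target, read by paw edema, with stated times of 30 min and 1 h, at a dose of 0.28 mmol/kg by the oral route; on this read-out higher numbers stand for more inhibition at the one dose given (going by the name of the read-out) and lower numbers for less inhibition:
compound 1 `CCNC(=O)c1nc(-c2cc(OC)c(OC)c(OC)c2)n(-c2ccc(OC)cc2)n1` gives 60%
compound 2 `COc1ccc(-n2nc(C(=O)Nc3ccc(C)cc3)nc2-c2cc(OC)c(OC)c(OC)c2)cc1` gives 38%
compound 3 `COc1ccc(-n2nc(C(=O)Nc3ccc(O)cc3)nc2-c2cc(OC)c(OC)c(OC)c2)cc1` gives 36%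

Compound 3 stands lowest of the three numbers. Its nearest neighbour is compound 2: the step of a number 2 percentage points lower from compound 2 to compound 3 (within the scatter) lies within the scatter, so the two cannot be ordered. The only large gaps in the set come from the ethyl-to-aryl exchange on the amide-type nitrogen: a number 22 percentage points lower from compound 1 to compound 2 (beyond the scatter) and a number 24 percentage points lower from compound 1 to compound 3 (beyond the scatter).

Compound 4 `COc1ccc(-n2nc(C(=O)Nc3ccccc3)nc2-c2cc(OC)c(OC)c(OC)c2)cc1` differs from compound 3 in one place: hydrogen in place of hydroxy on an aromatic carbon. For the measured compounds named here, the step that bears on this is the one between compound 2 and compound 3, where methyl and hydroxy on that same aromatic carbon gave numbers within the scatter of each other. Going by the values given here, no measured pair removes the para group altogether, so that part of the change is untested; the large steps from compound 1 concern a different position and do not bear on it.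

On this basis no step beyond the scatter is expected in this assay for compound 4. Compound 4 is estimated at 37%, with a range of 24% to 50%, which means an expected step of a number 1 percentage points higher from compound 3 to compound 4 (within the scatter).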

Compound 4, a percentage reported as inhibition, in the whole organism at one dose (the size of the read-out at that dose, not a potency): 45%
For compound 4 the middle estimate is 8 percentage points below the measured one; low and high end bracket the measured number.
By their numbers in this assay, from the lowest: compounds 3, 2 and 4 (each within the scatter of the next); then compound 1.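

With hydrogen in place of hydroxy on the aromatic carbon of the anilide, this assay gives a number 9 percentage points higher from compound 3 to compound 4 (within the scatter) and, against methyl at the same carbon, a number 7 percentage points higher from compound 2 to compound 4 (within the scatter), so hydroxy, methyl and hydrogen at this place cannot be told apart in these three compounds. For the compounds shown here, the unsubstituted phenyl amide still stands apart from the ethyl amide, with a number 15 percentage points lower from compound 1 to compound 4 (beyond the scatter), which shows that the gap from compound 1 does not depend on a group at this aromatic carbon: it is present for phenyl, 4-methylphenyl and 4-hydroxyphenyl alike, with no compound here going against it. No measurement at hand accounts for either finding.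

What the compounds shown leave open is whether a group such as an amine, a carboxylic acid or a methoxy at this aromatic carbon would give a number outside the scatter of these three. Also open, on these data alone, is how a longer chain than ethyl, or a benzyl group, on the amide nitrogen would compare with compound 1 and the phenyl amide compound 4 at this one dose.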